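The source may hold more compounds than are shown below. What is called first, only, known or untested is meant among the compounds shown, and "the series" means these compounds.

Measured compounds in this series:

compound 1: `O=S(=O)(NCCCNCc1cccc2ccccc12)c1cc(C(F)(F)F)cc(C(F)(F)F)c1` — 2800 nM
compound 2: `O=S(=O)(NCCCCCCNCc1ccc(Br)cc1)c1ccc2c(c1)OCC2` — 13000 nM
compound 3: `O=S(=O)(NCCCNCC1COc2ccccc2O1)c1cc(C(F)(F)F)cc(C(F)(F)F)c1` — 2600 nM

In a functional assay on MIA PaCa-2 cells (Homo sapiens) for inhibition, read by MTT assay, with a stated time of 72 h (on this read-out higher numbers stand for weaker inhibition of growth and lower numbers for stronger inhibition of growth), compound 2 gives 13000 nM, the highest of the three numbers. Compound 1 gives 2800 nM and compound 3 gives 2600 nM, each lower than compound 2 by a margin beyond the scatter, but both also differ from compound 2 in more than one place, so their gap to compound 2 cannot be assigned to any single group.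

Compound 4 is `Cc1ccc(S(=O)(=O)NCCCCCCNCc2ccc(Br)cc2)cc1`. Against compound 2 the change is a group of 7 heavy atoms (7 carbon; one six-membered aromatic ring of carbon only) in place of a group of 9 heavy atoms (8 carbon, 1 oxygen; one five-membered non-aromatic ring with 1 hetero atom, one six-membered aromatic ring of carbon only), on a sulfonyl sulfur. Among the compounds with values here, the only step measured within a single position, a 1.1-fold lower number from compound 1 to compound 3 (0.03 log units; within the scatter), alters the group on the saturated chain carbon bound to the amine nitrogen and leaves the sulfonyl side untouched, so it does not bear on this change. Within the data shown here, no measured step touches the group on the sulfonyl sulfur. With nothing to anchor a direction, compound 4 is expected to stay close to compound 2, with a step of a 1.2-fold higher number from compound 2 to compound 4 (0.06 log units; within the scatter) that is not expected to exceed the scatter. The estimate for compound 4 in this assay is 15000 nM, within a range of 5000 nM to 45000 nM.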

Compound 4, concentration for 50% growth inhibition: 12300 nM
Estimate against measurement, compound 4: 1.2-fold (0.09 log units) above; measured number inside the range.
By their numbers in this assay, from the lowest: compounds 3 and 1 (each within the scatter of the next); then compounds 4 and 2 (each within the scatter of the next).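

In this assay, the group on the sulfonyl sulfur now has its first measured step, a 1.1-fold lower number from compound 2 to compound 4 (0.02 log units; within the scatter). In this one pair, 4-methylphenyl replaces the group holding the five-membered non-aromatic ring and its hydrogen-bond acceptor, and the read-out does not move beyond the scatter, so neither that ring nor that acceptor is shown to be needed here. No measurement on hand accounts for this result.

Still open, going by these compounds, is whether a different kind of group on the sulfonyl sulfur, such as a phenyl ring carrying a carboxylic acid or an amine, would move the number beyond the scatter. Also open, on these data alone, is whether the same change would behave alike on the core of compound 1, and pairs differing in more than one place cannot be read on this point.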